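Homologation at Two Oxygens on a Shared Core

This account rests on a few compounds, and the source may have more. Where it says the series, first, only, none or still open, it means among the compounds named here.

Compound 1 `CCOC(=O)c1c(C)coc1-c1ccc2c(CC)cccc2c1OC` was tested in a functional assay on MDA-MB-231 cells (Homo sapiens) for cytotoxicity, read by MTT assay, with a stated time of 72 h (a higher number here means that more compound is needed for the effect, a lower number that less compound is needed), where compound 1 gives 3.9 ug/mL. Compound 2 `CCCOC(=O)c1c(C)coc1-c1ccc2c(CC)cccc2c1OC` differs by methyl in place of hydrogen on a saturated chain carbon, two bonds along the chain from an oxygen next to a carbonyl group. In this assay compound 2 reaches only a limit, > 10 ug/mL. That change made an at least 2.5-fold higher number from compound 1 to compound 2 (0.40 log units; beyond the scatter). Compound 3 `CCc1cccc2c(OC)c(-c3occ(C)c3COC)ccc12` has a different core; the two cores differ by methoxymethyl in place of ethoxycarbonyl on an aromatic carbon, and in this assay compound 3 gives 9.7 ug/mL. Compound 4 `CCOc1c(-c2occ(C)c2COC)ccc2c(CC)cccc12` differs from compound 3 by methyl in place of hydrogen on a saturated chain carbon bound to an oxygen on an aromatic ring. Among the measured compounds shown here, this is the same kind of change as the one between compound 1 and compound 2, but the place is not the same: there the entering methyl sits on a saturated chain carbon two bonds along the chain from an oxygen next to a carbonyl group, here on a saturated chain carbon bound to an oxygen on an aromatic ring. Compound 4 is expected to show a 2.1-fold higher number from compound 3 to compound 4 (0.31 log units; beyond the scatter), an expectation resting on the earlier step of an at least 2.5-fold higher number from compound 1 to compound 2 (0.40 log units; beyond the scatter). Compound 4 is therefore estimated at 20 ug/mL, between 7 ug/mL and 60 ug/mL, and may well come back only as a limit.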

Compound 4, concentration for half-maximal effect: > 10 ug/mL
Compound 4 was reported as a limit; the forecaster's own chance of this, stated with the estimate: 65%; the middle value lies beyond the limit too.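

In this assay compound 4 reaches only a limit, > 10 ug/mL. The methoxy to ethoxy change therefore gives an at least 1.0-fold higher number from compound 3 to compound 4 (0.01 log units; that floor lies within the scatter), which is a floor and not a size. Set beside the same kind of change on the ester side, where the methyl enters at a different place, the result shows no reversal of direction but does not show that the size carries from one core to the other: the same change on two cores in this assay, an at least 2.5-fold higher number (0.40 log units; beyond the scatter) from compound 1 to compound 2 and an at least 1.0-fold higher number (0.01 log units; that floor lies within the scatter) from compound 3 to compound 4; the limit leaves it open whether they differ.

The compounds shown leave open how either core would respond to a longer chain such as butyl, or to a carboxylic acid or an amine in place of ethoxycarbonyl. How far compound 2 and compound 4 truly lie past the limit also remains open: the limit of > 10 ug/mL in this assay, at which 2 of the 4 values shown sit.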